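A few compounds are considered here, and "the series" means these few. Any claim that something is new, unique, unknown or untested is made for them only; others in the source may bear on it.

In a functional assay on RKO cells (Homo sapiens) for cytotoxicity, read by resazurin assay, with a stated time of 72 h (on this read-out higher numbers stand for weaker inhibition and lower numbers for stronger inhibition), compound 1 `Cc1cn(-c2csc(Nc3ccc(Br)cc3)n2)c(C)n1` gives 45000 nM and compound 2 `Cc1nc2ccccc2n1-c1csc(Nc2cccc(Br)c2)n1` gives 85000 nM. These two values lie within the scatter of each other, so compound 2 stands level with compound 1 on the numbers available. Compound 3 `Cc1nc2ccccc2n1-c1csc(Nc2ccccc2)n1` differs from compound 2 by one change, hydrogen in place of bromo on an aromatic carbon, meta to a large group. For the measured compounds named here, no measured pair isolates this change, so the data do not show directly what removing the bromo does. The expectation therefore starts from compound 2 at 85000 nM. No shift beyond the scatter is expected in this assay, in either direction, and the estimated step is a 1.1-fold higher number from compound 2 to compound 3 (0.02 log units; within the scatter). For compound 3 the expected value is 90000 nM, with an estimated range of 35000 nM to 200000 nM.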

Compound 3, half-maximal inhibitory concentration: 50000 nM
Compound 3: the middle estimate sits 1.8-fold (0.26 log units) above what was measured; the range from low to high includes it.
By their numbers in this assay, from the lowest: compounds 1, 3 and 2 (each within the scatter of the next).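

In this assay, for the compounds shown here, the change from 3-bromophenyl to phenyl gives a 1.7-fold lower number from compound 2 to compound 3 (0.23 log units; within the scatter), the first direct reading of this change on an aromatic carbon, meta to a large group. With the pair level within the scatter, the bromo at this position makes no measurable difference to the read-out; this holds for this one pair and on the core of compound 2 only. No measurement at hand gives a reason for the two compounds reading alike.

Open, going by these compounds, is whether another group at this place, such as an amine, a carboxylic acid or a methoxy group, would shift the number beyond the scatter. Also open, on these data alone, is whether hydrogen in place of bromo reads the same way on the core of compound 1.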